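Adding a Second Methoxy Group to Compound 1

The source may hold more compounds than are shown below. What is called first, only, known or untested is meant among the compounds shown, and "the series" means these compounds.

Within the data shown here, compound 1 `COc1ccc(-c2cc(/C=C/C(=O)c3ccc(N)cc3)[nH]n2)cc1` is the only member of this small set with a measured number. In a functional assay on SW-620 cells (Homo sapiens) for inhibition, read by sulforhodamine B assay, with a stated time of 48 h (on this read-out higher numbers stand for weaker inhibition of growth and lower numbers for stronger inhibition of growth), compound 1 gives 5410 nM. Compound 2 `COc1cc(-c2cc(/C=C/C(=O)c3ccc(F)c(F)c3)[nH]n2)cc(OC)c1OC` is reported in this assay only as a limit, > 100000 nM, not as a number. Compound 3 `COc1ccc(-c2cc(/C=C/C(=O)c3ccc(N)cc3)[nH]n2)cc1OC` differs from compound 1 by methoxy in place of hydrogen on an aromatic carbon. Among the measured compounds shown here, no measured pair shows this change, so the expected step is one within the usual scatter, with no clear direction, as a 1.3-fold higher number from compound 1 to compound 3 (0.11 log units; within the scatter) describes. Compound 3 is estimated at 7000 nM, with a range from 2500 nM to 25000 nM.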

Compound 3, concentration for total growth inhibition: 6940 nM
Estimate against measurement, compound 3: 1.0-fold (0.00 log units) above, within the range that was stated.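

In this assay the change gives a 1.3-fold higher number from compound 1 to compound 3 (0.11 log units; within the scatter) and so leaves growth inhibition within the usual scatter of repeated measurements. The aromatic carbon ortho to a methoxy group and meta to a large group therefore accepts this added methoxy with no clear gain or loss. Nothing shown here explains this outcome.

Open, on these data alone, is whether a hydroxyl, an amine or a longer ethoxy chain on this same carbon would also leave the number within the scatter. A single pair also cannot tell whether methoxy would behave alike on other carbons of this ring.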